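Swapping the aryl group: from ethoxyphenyl toward chloromethylphenyl

The source may report more compounds than this note shows. Statements on the series, on what has been measured and on what is new or still open speak of the compounds shown alone.

Measured compounds:
- compound 1 `CCOc1ccc(-c2cc(=O)c3c(o2)C(CC)(CC)C(=O)C(CC)=C3O)cc1`: 7.54 uM
- compound 2 `CCC1=C(O)c2c(oc(-c3cccc(F)c3)cc2=O)C(CC)(CC)C1=O`: 3.09 uM
- compound 3 `CCC1=C(O)c2c(oc(-c3ccccc3C(F)(F)F)cc2=O)C(CC)(CC)C1=O`: 43.1 uM

In a functional assay on KBVIN cells (Homo sapiens) for antiproliferative activity, read by sulforhodamine B assay, with a stated time of 3 days (a higher number here means that more compound is needed for the effect, a lower number that less compound is needed), compound 1 gives 7.54 uM, the second highest of the three numbers; compound 2 sits closest with 3.09 uM, while compound 3 lies furthest away with 43.1 uM. All three share the same core and differ only in the aryl group attached to it.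

Compound 4 `CCC1=C(O)c2c(oc(-c3ccc(C)c(Cl)c3)cc2=O)C(CC)(CC)C1=O` has not yet been measured. It differs from compound 1 in one place: 3-chloro-4-methylphenyl in place of 4-ethoxyphenyl on an aromatic carbon.

Within the data shown here, only one measured step bears on this kind of change: a 2.4-fold lower number from compound 1 to compound 2 (0.39 log units; beyond the scatter). That swap of one aryl group for another moved the number down by a modest amount, beyond the scatter. Compound 4 carries a halogen on its aryl ring as compound 2 does, so a step of similar size and direction is expected here, though the added methyl leaves room for a weaker outcome. The expected step is a 1.9-fold lower number from compound 1 to compound 4 (0.28 log units; within the scatter).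

Compound 4 is therefore estimated at 4 uM in this assay, within a range from 1.5 uM to 12 uM.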

Compound 4, concentration for half-maximal effect: 2.15 uM
The estimate for compound 4 lay 1.9-fold (0.27 log units) above the measured number; the range from low to high includes it.
By their numbers in this assay, from the lowest: compounds 4 and 2 (each within the scatter of the next); then compound 1; then compound 3.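

In this assay, a second replacement of the 4-ethoxyphenyl group also lowers the number (a 3.5-fold lower number from compound 1 to compound 4 (0.54 log units; beyond the scatter)), so the drop seen with 3-fluorophenyl is no longer a single case at this position. The 3-chloro-4-methylphenyl and 3-fluorophenyl groups cannot be told apart here (a 1.4-fold lower number from compound 2 to compound 4 (0.16 log units; within the scatter)), so two different substituted rings give numbers within the usual scatter of each other. Nothing measured here explains why these aryl groups give these numbers.

On these data alone, it remains open whether the chlorine or the methyl alone would give a similar number. How a ring carrying an amine or a carboxylic acid would behave at this position is also unknown.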